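Methoxyphenyl replaces hydroxyphenyl on the shared core

The source may report more compounds than this note shows. Statements on the series, on what has been measured and on what is new or still open speak of the compounds shown alone.

Three compounds share one core and differ in the aryl group attached to it. In a functional assay on KBVIN cells (Homo sapiens) for antiproliferative activity, read by sulforhodamine B assay, with a stated time of 3 days (a higher number here means that more compound is needed for the effect, a lower number that less compound is needed), compound 1 `CCC1=C(O)c2c(oc(-c3ccc(C(C)C)cc3)cc2=O)C(CC)(CC)C1=O` gives 1.08 uM, compound 2 `CCC1=C(O)c2c(oc(-c3ccc(O)cc3)cc2=O)C(CC)(CC)C1=O` gives 20.6 uM, and compound 3 `CCC1=C(O)c2c(oc(-c3cccc(OC(F)(F)F)c3)cc2=O)C(CC)(CC)C1=O` gives 9.95 uM. Compound 2 stands with the highest number of the three: compound 3 comes nearest, and compound 1 lies furthest away. Among the compounds with values here, the single measured step, a 19-fold higher number from compound 1 to compound 2 (1.28 log units; beyond the scatter), shows that the hydroxy substituent goes with a much higher number than the isopropyl one.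

Compound 4 `CCC1=C(O)c2c(oc(-c3ccccc3OC)cc2=O)C(CC)(CC)C1=O` is not yet measured. Its change from compound 2 is 2-methoxyphenyl in place of 4-hydroxyphenyl on an aromatic carbon. Within the data shown here, no measured step swaps these two aryl groups; the only step that bears on the change is the one from compound 1 to compound 2, and in compound 4 the hydroxy group is again removed, while the methoxy group sits on a different position of the ring. In this assay compound 4 is therefore expected to give a lower number than compound 2, by a step of a 3.4-fold lower number from compound 2 to compound 4 (0.54 log units; beyond the scatter), though smaller than the reversed hydroxy-to-isopropyl step. Compound 4 is estimated at 6 uM, with a range from 2 uM to 20 uM.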

Compound 4, concentration for half-maximal effect: 3.26 uM
Compound 4: middle estimate off by 1.8-fold (0.26 log units), on the high side; measured number inside the range.
By their numbers in this assay, from the lowest: compound 1; then compound 4; then compound 3; then compound 2.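

In this assay, the change to 2-methoxyphenyl gives a 6.3-fold lower number from compound 2 to compound 4 (0.80 log units; beyond the scatter), so a substantially lower number at this aromatic carbon does not depend on 4-isopropylphenyl alone. The 2-methoxyphenyl group does not match that group, however, with a 3.0-fold higher number from compound 1 to compound 4 (0.48 log units; beyond the scatter). Nothing shown here gives a reason for either step.

On these data alone, whether the lower number of compound 4 follows from the loss of the hydroxy group, the gain of the methoxy group or the changed place of the substituent stays open: this one change alters all three at once. As far as these compounds go, how an amine or a longer alkoxy chain on the same aryl ring would compare in this assay is also open.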